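This account rests on a few compounds, and the source may have more. Where it says the series, first, only, none or still open, it means among the compounds named here.

Compound 2 (`COc1ccccc1C(=O)NC(=O)Nc1ccc(N2CCCCC2)c(C(F)(F)F)c1`) stands at the floor of what a physicochemical assay for solubility, in phosphate buffer, at pH 7.4 (a lower number here means a less soluble compound, a higher number a more soluble compound), can report. In this assay compound 2 gives < 1 ug/mL, which is a limit of the assay and not a number. Among the compounds with values here, its one measured neighbour, compound 1 (`COc1ccccc1C(=O)NC(=O)Nc1ccc(-c2nccs2)c(C(F)(F)F)c1`), sits in the same place: in this assay compound 1 gives < 1 ug/mL, again a limit rather than a number. Within the data shown here, the single measured step, a step that the two limits leave unreadable from compound 1 to compound 2, is therefore not readable, because of the limit of < 1 ug/mL in this assay, at which 2 of the 2 values shown sit. Compound 3 (`COc1ccccc1C(=O)NC(=O)Nc1ccc(N2CCCCC2)c(Cl)c1`) differs from compound 2 by chloro in place of trifluoromethyl on an aromatic carbon. No measured step touches this change, and the one step that exists gives neither direction nor size, so the numbers shown offer no guide to how this assay will respond; the expectation below rests on the starting point of compound 2 alone. The step from compound 2 to compound 3 in this assay is expected to be an at least 1.5-fold higher number from compound 2 to compound 3 (0.17 log units; that floor lies within the scatter), though a result that is again only a limit is at least as likely as a number. For compound 3 the estimated solubility in this assay is 1.5 ug/mL, with a range from 0.3 ug/mL to 8 ug/mL.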

Compound 3, solubility: < 1 ug/mL
Compound 3 was reported as a limit; the forecaster's own chance of this, stated with the estimate: 55%; middle value at least 1.5-fold (0.17 log units) away from the limit.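

No new step can be read from compound 2 to compound 3 in this assay, because both compounds give a limit of the assay rather than a number: the limit of < 1 ug/mL in this assay, at which 3 of the 3 values shown sit.

The compounds shown leave open whether either change, piperidin-1-yl in place of 1,3-thiazol-2-yl or chloro in place of trifluoromethyl, moves the read-out at all, and in which direction.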